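This account rests on a few compounds, and the source may have more. Where it says the series, first, only, none or still open, it means among the compounds named here.

Compound 1 `Cn1nc(-c2nnc(-c3ccccc3Cl)o2)c2ccccc21` and compound 2 `Cc1cccc(-c2nnc(-c3nn(C)c4ccccc34)o2)c1` share one core that carries an aryl group on the five-membered ring. In an ADME assay on L02 cells (Homo sapiens) for cytotoxicity, read by MTT assay, with a stated time of 72 h (a lower number here means a stronger inhibitor, a higher number a weaker inhibitor), compound 1 gives only a limit, > 100000 nM. In this assay compound 2 likewise gives only a limit, > 100000 nM. The step that the two limits leave unreadable from compound 1 to compound 2 is therefore unreadable, and the limit of > 100000 nM in this assay, at which 2 of the 2 values shown sit, is all that the measured pair shows. Compound 3 `Cn1nc(-c2nnc(-c3ccc(Cl)cc3)o2)c2ccccc21` differs from compound 2 by 4-chlorophenyl in place of 3-methylphenyl on an aromatic carbon. Among the compounds with values here, no measured step bears readably on this change. Compound 3 is expected to remain at the limit, the expected step of a number no higher from compound 2 to compound 3 (the limit leaves the size open) being none beyond the scatter, with an estimate of 100000 nM in the range 50000 nM to 200000 nM.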

Compound 3, half-maximal inhibitory concentration: > 100000 nM
Compound 3 ended at the assay's limit; the forecaster's own chance of this, stated with the estimate: 85%; the middle value sits exactly at the limit.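

Compound 2 and compound 3, like compound 1, give only limits in this assay, so no new step can be read: the limit of > 100000 nM in this assay, at which 3 of the 3 values shown sit.

On these data alone, how the 2-chlorophenyl, 3-methylphenyl and 4-chlorophenyl compounds compare in this assay stays open.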